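Swapping Hydrogen for Trifluoromethyl on a Methoxymethyl Arm

The source may hold more compounds than are shown below. What is called first, only, known or untested is meant among the compounds shown, and "the series" means these compounds.

Compound 2 `CCc1cccc2c(OC)c(-c3occ(C)c3COC)ccc12` and compound 1 `CCc1cccc2c(OC)c(-c3occ(C)c3C(=S)OC)ccc12` share one core and differ only in the group attached to an aromatic carbon. In a functional assay on ZR-75-1 cells (Homo sapiens) for cytotoxicity, read by MTT assay, with a stated time of 72 h (a higher number here means that more compound is needed for the effect, a lower number that less compound is needed), compound 1 gives 5.8 ug/mL, and compound 2 gives 9.7 ug/mL. On the numbers shown, compound 2 stands at the top of the two, yet the only measured step, a 1.7-fold higher number from compound 1 to compound 2 (0.22 log units; within the scatter), is within the scatter, so the two cannot be told apart. Compound 3 `CCc1cccc2c(OC)c(-c3occ(C)c3COCC(F)(F)F)ccc12` is not yet measured. It differs from compound 2 by trifluoromethyl in place of hydrogen on a saturated chain carbon bound to an oxygen on a saturated carbon; cut one bond further out, this reads methoxymethyl to (2,2,2-trifluoroethoxy)methyl. Within the data shown here, no measured step touches this chain carbon, and the single step in hand was within the scatter, so no step beyond the scatter is expected in this assay. The expected step is a 1.1-fold lower number from compound 2 to compound 3 (0.06 log units; within the scatter). Compound 3 is therefore estimated at 8.5 ug/mL, with a range from 3 ug/mL to 25 ug/mL.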

Compound 3, concentration for half-maximal effect: 5.3 ug/mL
The estimate for compound 3 lay 1.6-fold (0.21 log units) above the measured number; measured number inside the range.
By their numbers in this assay, from the lowest: compounds 3, 1 and 2 (each within the scatter of the next).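

Among these compounds, putting trifluoromethyl in place of hydrogen on this saturated chain carbon bound to an oxygen gives a 1.8-fold lower number from compound 2 to compound 3 (0.26 log units; within the scatter) in this assay, so the added fluorine-bearing group produces no step that can be told from noise at this carbon. Comparing the thioester-bearing compound with the new arm gives a 1.1-fold lower number from compound 1 to compound 3 (0.04 log units; within the scatter), which means that all three groups on this aromatic carbon now read alike in this assay. Nothing available explains this flat result.

The compounds shown leave open whether any change on this arm can move the number beyond the scatter. A longer chain, an amine or a carboxylic acid at the end of the arm would test this, and none of them appears among these compounds.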